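Replacing (ethylcarbamoyl)amino with dipropylamino on the shared core

A few compounds are considered here, and "the series" means these few. Any claim that something is new, unique, unknown or untested is made for them only; others in the source may bear on it.

Within the data shown here, in a functional assay on A2780 cells (Homo sapiens) for antiproliferative activity, read by MTT assay, with a stated time of 48 h (a higher number here means a weaker inhibitor, a lower number a stronger inhibitor), compound 1 `CCNC(=O)Nc1nc(-c2ccc(OCC)cc2)c(-c2cc(OC)c(OC)c(OC)c2)s1` gives 1.3 nM and holds the lowest number measured so far. In this assay compound 3 `CCOc1ccc(-c2sc(N)nc2-c2cc(OC)c(OC)c(OC)c2)cc1` gives 8.6 nM as its result, and its gap from compound 1 lies beyond the usual scatter of repeated measurements. Compound 2 `CCOc1ccc(-c2nc(N(Cc3ccccc3)Cc3ccccc3)sc2-c2cc(OC)c(OC)c(OC)c2)cc1` is recorded at > 5000 nM as its result, and this is a limit of the assay rather than a number.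

The next compound is compound 4 `CCCN(CCC)c1nc(-c2ccc(OCC)cc2)c(-c2cc(OC)c(OC)c(OC)c2)s1` and it has not yet been measured. It keeps the core of compound 1 but carries dipropylamino in place of (ethylcarbamoyl)amino on an aromatic carbon.

Among the measured compounds shown here, no measured pair isolates this swap, so the expectation rests on thin ground. A large move toward a higher number, beyond the scatter, is expected in this assay for this change. Compound 2 is the main reason for that expectation, standing at the limit of > 5000 nM in this test. Compound 3 keeps a low number at 8.6 nM and so argues against a total loss, which widens the expected range. The expected change is a 620-fold higher number from compound 1 to compound 4 (2.79 log units; beyond the scatter) as estimated here. Compound 4 is estimated at 800 nM with an expected range from 60 nM to 5000 nM in this measurement.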

Compound 4, half-maximal inhibitory concentration: > 5000 nM
Compound 4 gave a limit, no number; the forecaster's own chance of this, stated with the estimate: 30%; middle value at least 6.2-fold (0.79 log units) from the limit.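

In this assay, dipropylamino in place of (ethylcarbamoyl)amino gives an at least 3800-fold higher number from compound 1 to compound 4 (3.58 log units; beyond the scatter), so the low number of compound 1 does not survive this single change on the shared core. Compound 4 stands at > 5000 nM, which is a limit of the assay and not a number, so the step marks only the smallest size the change can have. Compound 4 now sits at the same limit as compound 2, which carries dibenzylamino at the same place, so two different groups with two carbon chains or arms on the nitrogen end up there: the limit of > 5000 nM in this assay, at which 2 of the 4 values shown sit.

The swap removes the carbonyl and the hydrogen-bond donors of (ethylcarbamoyl)amino together, and it also brings in the two propyl chains, so the compounds shown cannot tell which of these changes matters. A propylamino group or an acetylamino group on the same aromatic carbon would begin to separate these changes, since each keeps a hydrogen on the nitrogen while only the second keeps a carbonyl.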